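The compounds below may be only part of what the source reports. "The series", "measured", "known", "first", "only" and "open" are said of these compounds alone.

Working notes on the series, read out in a physicochemical assay for solubility, measured as thermodynamic solubility; a higher number here means a more soluble compound, a lower number a less soluble compound. Among the compounds with values here, only two compounds carry a number so far. Compound 1 `COc1ccc(OC)c(-c2ccc(NC(=O)c3ccncc3F)cc2)c1` gives 0.28 ug/mL, and compound 2 `O=C(O)c1cccc(-c2cn(-c3ccc(-c4ccc5c(c4)OCCO5)cc3)nn2)c1` gives 668 ug/mL. Compound 2 is therefore the higher of the two, by a gap well beyond the scatter. Within the data shown here, these two compounds differ in more than one place, so their gap cannot be tied to any single structural feature, and no measured single-place step is available as a guide.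

The next compound is compound 3 `COc1ccc(F)c(-c2ccc(-n3cc(-c4cccc(C(=O)O)c4)nn3)cc2)c1`, which differs from compound 2 at one place: 2-fluoro-5-methoxyphenyl in place of 2,3-dihydro-1,4-benzodioxin-6-yl on an aromatic carbon. In words, 2-fluoro-5-methoxyphenyl stands in place of 2,3-dihydro-1,4-benzodioxin-6-yl on an aromatic carbon, para to a large group. The rest of the structure is unchanged, so the anchor for the expectation is compound 2 at 668 ug/mL. No change beyond the scatter is expected in this assay, with a slight fall as the likelier direction. The estimated move is a 1.3-fold lower number from compound 2 to compound 3 (0.13 log units; within the scatter). For compound 3 the expected value is 500 ug/mL, with an estimated range of 130 ug/mL to 1400 ug/mL.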

Compound 3, solubility: 1170 ug/mL
The estimate for compound 3 lay 2.3-fold (0.37 log units) below the measured number, and the stated range covers the measured number.
By their numbers in this assay, from the lowest: compound 1; then compounds 2 and 3 (each within the scatter of the next).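

Within the data shown here, this is the first single-place step, and it places 2-fluoro-5-methoxyphenyl and 2,3-dihydro-1,4-benzodioxin-6-yl within the scatter of each other in this assay on this aromatic carbon, para to a large group. The exchange gives a 1.8-fold higher number from compound 2 to compound 3 (0.24 log units; within the scatter) even though it removes the six-membered non-aromatic ring and goes from 10 heavy atoms to 9 and from 2 hydrogen-bond acceptors to 1, so on this core the position accepts both aryl groups without a change that can be read in this assay. No supporting data bear on why the two values lie so close, and no cause can be assigned to the step.

Open, on these data alone, is whether an aliphatic amine, a hydroxyl or a longer alkoxy chain on this aromatic carbon would give a step beyond the scatter. Also open, as far as these compounds go, is whether the same exchange gives a step of this size on a core without the carboxylic acid, and compound 1 does not settle that, as it differs from compound 2 in more than one place.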